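From Pyrrolidine to Isopropylpiperazine on a Benzylic Carbon

This account rests on a few compounds, and the source may have more. Where it says the series, first, only, none or still open, it means among the compounds named here.

In a functional assay on A549 cells (Homo sapiens) for cytotoxicity, read by MTT assay, with a stated time of 72 h (on this read-out higher numbers stand for weaker inhibition and lower numbers for stronger inhibition), compound 1 `COc1ncc(-c2ccc3nccc(-c4ccc(C)cc4)c3c2)cc1NS(=O)(=O)c1ccc(F)cc1F` gives 1240 nM, while compound 2 `COc1ncc(-c2ccc3nccc(-c4ccc(CN5CCCC5)cc4)c3c2)cc1NS(=O)(=O)c1ccc(F)cc1F` gives 37.5 nM, the lowest of the two numbers shown. For the measured compounds named here, the only measured step, a 33-fold lower number from compound 1 to compound 2 (1.52 log units; beyond the scatter), came from pyrrolidin-1-yl in place of hydrogen on a saturated chain carbon bound to an aromatic carbon. Compound 3 `COc1ncc(-c2ccc3nccc(-c4ccc(CN5CCN(C(C)C)CC5)cc4)c3c2)cc1NS(=O)(=O)c1ccc(F)cc1F` differs from compound 2 by 4-isopropylpiperazin-1-yl in place of pyrrolidin-1-yl on a saturated chain carbon bound to an aromatic carbon. That earlier step bears on this change only loosely, since compound 3, like compound 2, keeps a nitrogen-containing ring on that chain carbon, so no step beyond the scatter is expected in this assay, a 1.1-fold higher number from compound 2 to compound 3 (0.03 log units; within the scatter). For compound 3 the estimated value is 40 nM, within a range of 12 nM to 130 nM.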

Compound 3, half-maximal inhibitory concentration: 1.9 nM
Compound 3: middle estimate off by 21-fold (1.32 log units), on the high side, outside the stated range (below it).
By their numbers in this assay, from the lowest: compound 3; then compound 2; then compound 1.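

In this assay, there is a 20-fold lower number from compound 2 to compound 3 (1.30 log units; beyond the scatter) when 4-isopropylpiperazin-1-yl replaces pyrrolidin-1-yl, so the choice of ring on the saturated chain carbon bound to an aromatic carbon still matters once a nitrogen-containing ring is present. Measured against hydrogen at this position, there is a 650-fold lower number from compound 1 to compound 3 (2.81 log units; beyond the scatter) for the same group, more than pyrrolidin-1-yl alone had shown. Nothing measured here explains this difference. Going by these compounds, it remains open whether the piperazine ring or its isopropyl group carries the step. An unsubstituted piperazine or a morpholine on that chain carbon would help separate the two.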